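The compounds below may be only part of what the source reports. "The series", "measured", "known", "first", "only" and "open" are said of these compounds alone.

Measured compounds:
compound 1 `Cn1c(-c2ccc(C#N)cc2)cnc1NC(=O)c1ccc(F)cc1` – > 50000 nM
compound 2 `Cn1c(-c2ccc(F)cc2)cnc1NC(=O)c1ccc(F)cc1` – > 100000 nM

Both readings in a toxicity assay on THP-1 cells (Homo sapiens) for inhibition (on this read-out higher numbers stand for lower toxicity in this test and lower numbers for higher toxicity in this test), are limits of the assay rather than numbers. Compound 1 stands at a limit, (the limit of > 50000 nM in this assay, at which 1 of the 2 values shown sits). Compound 2 stands at a limit, (the limit of > 100000 nM in this assay, at which 1 of the 2 values shown sits). Going by the values given here, the only measured step, a step that the two limits leave unreadable from compound 1 to compound 2, cannot be read, because the limit of > 100000 nM in this assay, at which 1 of the 2 values shown sits, and the limit of > 50000 nM in this assay, at which 1 of the 2 values shown sits, leave no number at either end; all that can be said is that neither compound showed measurable toxicity up to the highest concentration tested.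

Compound 3 `COc1ccccc1-c1cnc(NC(=O)c2ccc(F)cc2)n1C` is not yet measured. It differs from compound 2 in one place: 2-methoxyphenyl in place of 4-fluorophenyl on an aromatic carbon. Among the compounds with values here, no measured step covers this kind of change, so there is nothing that points either way. What the two measured compounds show is that the shared core of compound 2 has so far given only limits in this assay, and compound 3 is expected to behave alike. Compound 3 is estimated at 100000 nM, within 30000 nM to 200000 nM, most likely again reported as a limit. That estimate means a step of a number no higher from compound 2 to compound 3 (the limit leaves the size open), none beyond the scatter.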

Compound 3, half-maximal cytotoxic concentration: > 100000 nM
Compound 3: only a limit was reported; the forecaster's own chance of this, stated with the estimate: 80%; the middle value lies on the limit itself.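

In this assay the steps from compound 2 to compound 3 and from compound 1 to compound 3 cannot be read: all three compounds give limits, not numbers. Compound 3 stands at a limit: the limit of > 100000 nM in this assay, at which 2 of the 3 values shown sit. From the compounds shown here alone, what stays open is how far apart the three compounds lie, and at what concentration, if any, each would become toxic to these cells.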